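From methoxycarbonyl to methylsulfonyl on an amine nitrogen

The compounds below may be only part of what the source reports. "The series", "measured", "known", "first", "only" and "open" are said of these compounds alone.

Compound 2 `COC(=O)N1CCC(c2nccnc2OC2CN(c3ccc4ccccc4n3)C2)CC1` gives 138000 nM in a physicochemical assay for solubility, in phosphate buffer, at pH 7.4 (a lower number here means a less soluble compound, a higher number a more soluble compound), and compound 1 `OCCC1CCN(c2nccnc2OC2CN(c3ccc4ccccc4n3)C2)CC1` gives 84000 nM there, two values within the usual scatter of each other. Compound 3 `CS(=O)(=O)N1CCC(c2nccnc2OC2CN(c3ccc4ccccc4n3)C2)CC1` carries methylsulfonyl in place of methoxycarbonyl on an amine nitrogen in a ring, a change counted as methylsulfonyl in place of methoxycarbonyl on an amine nitrogen in a ring and not yet measured. Going by the values given here, no measured step tests this swap directly. The nearest guide is a 1.6-fold higher number from compound 1 to compound 2 (0.22 log units; within the scatter) and it stays within the scatter, though it concerns a different change, 1-(methoxycarbonyl)piperidin-4-yl in place of 4-(2-hydroxyethyl)piperidin-1-yl on an aromatic carbon. Among the compounds with values here, with only that step a 1.6-fold higher number from compound 1 to compound 2 (0.22 log units; within the scatter) to go on, no step beyond the scatter is expected in this assay here. The estimate amounts to a 1.5-fold lower number from compound 2 to compound 3 (0.19 log units; within the scatter) as the expected step. Compound 3 is expected at 90000 nM within an estimated range from 30000 nM to 220000 nM for repeated measurements.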

Compound 3, solubility: 181000 nM
Beside the measured number, compound 3's estimate is 2.0-fold (0.30 log units) below it; low and high end bracket the measured number.
By their numbers in this assay, from the lowest: compounds 1, 2 and 3 (each within the scatter of the next, the first and the last beyond it).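

On an amine nitrogen in a ring, methylsulfonyl in place of methoxycarbonyl gives a 1.3-fold higher number from compound 2 to compound 3 (0.12 log units; within the scatter) in this assay, so this swap of two groups of equal heavy-atom count cannot be told apart from repeat-measurement noise in this assay. Going by these compounds alone, the other new comparison, 1-(methylsulfonyl)piperidin-4-yl in place of 4-(2-hydroxyethyl)piperidin-1-yl on an aromatic carbon, gives a 2.2-fold higher number from compound 1 to compound 3 (0.33 log units; beyond the scatter) and is the first step in this short series to clear the scatter, though only modestly. No independent measurement is available to explain either step.

Open, from the compounds shown here alone, is what a plain methyl or an acetyl group on that same amine nitrogen would give in this assay. Also open, going by these compounds, is whether a carboxylic acid or a basic amine on a longer chain at that nitrogen would move the number further than these neutral groups do.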